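From chloro to iodo: expecting the cytotoxicity of compound 4

A few compounds are considered here, and "the series" means these few. Any claim that something is new, unique, unknown or untested is made for them only; others in the source may bear on it.

Compound 1 `O=c1oc2ccccc2c(=O)n1-c1ccc(Cl)cc1F` is the starting point. In an ADME assay on RAW264.7 cells (Mus musculus) for cytotoxicity, read by MTT assay, with a stated time of 24 h (a lower number here means that less compound is tolerated, a higher number that more compound is tolerated), compound 1 gives 26500 nM. Compound 2 `COc1ccc2c(=O)n(-c3ccc(Cl)cc3F)c(=O)oc2c1` carries a methoxy group on its core; in this assay compound 2 reaches only a limit of the assay, > 40000 nM, not a number. Compound 3 `COc1ccc(C(=O)Nc2ccc(Cl)cc2F)cc1` is an open amide rather than a fused core; in this assay compound 3 likewise stops at a limit, > 40000 nM. Within the data shown here, the single comparable step runs an at least 1.5-fold higher number from compound 1 to compound 2 (0.17 log units; that floor lies within the scatter). Among the measured compounds shown here, compound 1 therefore stands as the only compound with a true number, against (the limit of > 40000 nM in this assay, at which 2 of the 3 values shown sit).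

Compound 4 `O=c1oc2ccccc2c(=O)n1-c1ccc(I)cc1F` differs from compound 1 in one place: iodo in place of chloro on an aromatic carbon. For the measured compounds named here, no measured step changes a halogen, so the methoxy step gives no direct guide; it shows only that one small change on the core moved the number no further than the scatter allows. An exchange of one halogen for another is expected to behave similarly, with no shift beyond the scatter in either direction. The estimate for compound 4 in this assay is therefore 24000 nM, with a range from 9000 nM to 40000 nM, which means an expected step of a 1.1-fold lower number from compound 1 to compound 4 (0.04 log units; within the scatter).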

Compound 4, half-maximal cytotoxic concentration: 23600 nM
Beside the measured number, compound 4's estimate is 1.0-fold (0.01 log units) above it; low and high end bracket the measured number.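

Among these compounds, this is the first step that changes the halogen on the outer aromatic ring rather than the core, and in this assay the exchange of chloro for iodo gives a 1.1-fold lower number from compound 1 to compound 4 (0.05 log units; within the scatter). A difference of this size is no larger than repeat measurements of one compound would be expected to show, so this position, para to a large group and meta to a fluoro group, takes iodo in place of chloro with no change that can be told from scatter. The result also adds a second true number on the shared core, whereas compound 2 and compound 3 each stop at a limit of the assay, not a number: the limit of > 40000 nM in this assay, at which 2 of the 4 values shown sit.

The compounds shown hold only chloro and iodo at this position, so it remains open whether an amine, a carboxylic acid or a longer alkyl chain there would leave the tolerated concentration just as unchanged. No pair shown alters the fluoro group either, and what that group adds to the number also remains open.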